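Benzofuran-to-ethynyl swap on the shared core

The source may report more compounds than this note shows. Statements on the series, on what has been measured and on what is new or still open speak of the compounds shown alone.

Compound 1 `COc1nc(N)nc2c1c(-c1cc3ccccc3o1)cn2[C@@H]1O[C@H](CO)[C@@H](O)[C@H]1O` stands at 12700 nM in a functional assay on CCRF-CEM cells (Homo sapiens), read by MTT assay, with a stated time of 72 h (on this read-out higher numbers stand for weaker inhibition and lower numbers for stronger inhibition), the highest of the two numbers obtained. Its nearest neighbour is compound 3 `COc1ncnc2c1c(-c1cc3ccccc3o1)cn2[C@@H]1O[C@H](CO)[C@@H](O)[C@H]1O`, which gives 5370 nM; the step of a 2.4-fold lower number from compound 1 to compound 3 (0.37 log units; beyond the scatter) is modest but beyond the scatter. Compound 2 `Nc1nc(N)c2c(-c3cc4ccccc4o3)cn([C@@H]3O[C@H](CO)[C@@H](O)[C@H]3O)c2n1` returns only a limit, > 20000 nM, and the step of an at least 1.5-fold higher number from compound 1 to compound 2 (0.19 log units; that floor lies within the scatter) is therefore bounded by that limit (the limit of > 20000 nM in this assay, at which 1 of the 3 values shown sits).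

The compound to be measured is compound 4 `C#Cc1cn([C@@H]2O[C@H](CO)[C@@H](O)[C@H]2O)c2nc(N)nc(OC)c12`. It differs from compound 1 in one place: ethynyl in place of 1-benzofuran-2-yl on an aromatic carbon.

Neither measured step bears on this change. The step from compound 1 to compound 3 and the step from compound 1 to compound 2 both alter the six-membered ring of the core, while the benzofuran-to-ethynyl swap sits on the five-membered ring and removes most of the aromatic bulk there. Going by the values given here, no measured compound lacks the 1-benzofuran-2-yl group, so the direction of the step in this assay cannot be read from the numbers at hand. The working expectation is a step of a 1.2-fold lower number from compound 1 to compound 4 (0.06 log units; within the scatter), that is, no change resolved beyond the scatter, with wide uncertainty in both directions. Compound 4 is accordingly estimated at 11000 nM, between 2500 nM and 40000 nM, and a limit result is a real possibility.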

Compound 4, half-maximal inhibitory concentration: > 100000 nM
Compound 4: no number, only a limit; the forecaster's own chance of this, stated with the estimate: 30%; middle value at least 9.0-fold (0.95 log units) from the limit.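

The place on the five-membered aromatic ring, two ring bonds from the ring nitrogen, is not indifferent to its substituent: in this assay, ethynyl in place of 1-benzofuran-2-yl gives an at least 7.8-fold higher number from compound 1 to compound 4 (0.89 log units; beyond the scatter). This is the first step shown at this place, and it shows that 1-benzofuran-2-yl cannot be exchanged here for the much smaller ethynyl without a loss beyond the scatter. Going by these compounds, compound 4 gives a limit and not a number, so the step is a floor and its true size stays unknown: the limit of > 100000 nM in this assay, at which 1 of the 4 values shown sits.

With only these two groups at this place, the compounds shown do not separate the loss of the fused aromatic rings from any contribution of ethynyl itself, a question that a phenyl or furan-2-yl group at the same carbon would address. Also open, on these data alone, is whether ethynyl gives a similar step on the cores of compound 2 and compound 3, where the six-membered ring carries other groups.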